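Amide swap on the weakly active compound 1

The compounds below may be only part of what the source reports. "The series", "measured", "known", "first", "only" and "open" are said of these compounds alone.

Compound 1 `Cc1noc(C)c1-c1nn(Cc2ccc(C(=O)NC3CC3)cc2)c(=O)c2ccccc12` gives > 100000 nM in a functional assay on HCT-116 cells (Homo sapiens) for antiproliferative activity, read by MTT assay, with a stated time of 72 h (on this read-out lower numbers stand for stronger inhibition and higher numbers for weaker inhibition), which is a limit of the assay and not a number. Compound 3 `O=C(Nc1ccccc1Cl)c1ccc(Nc2nn(Cc3ccc(C(=O)NC4CCCCC4)cc3)c(=O)c3ccccc23)cc1` gives > 100000 nM, again a limit. Within the data shown here, compound 1 thus stands at the limit of > 100000 nM in this assay, at which 2 of the 3 values shown sit, with no exact number to step from. Among the measured compounds shown here, compound 2 `Cn1cc(-c2nn(Cc3ccc(C(=O)NC4CC4)cc3)c(=O)c3ccccc23)cn1` gives 20100 nM, the only exact number so far.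

Compound 4 `Cc1noc(C)c1-c1nn(Cc2ccc(C(=O)NC3CCN(C)CC3)cc2)c(=O)c2ccccc12` keeps the core of compound 1 and carries 1-methylpiperidin-4-yl in place of cyclopropyl on an amide-type nitrogen. For the measured compounds named here, no measured step touches that nitrogen. Going by the values given here, the one measured step, an at least 4.9-fold lower number from compound 1 to compound 2 (0.69 log units; beyond the scatter), lies beyond the scatter but acts on an aromatic carbon, so it bears only indirectly and guides the size alone. On that guide, a modest move towards a lower number is expected in this assay, and the expected step is an at least 2.5-fold lower number from compound 1 to compound 4 (0.39 log units; beyond the scatter). A reading at the limit remains quite possible. Compound 4 is estimated at 40000 nM, with an expected range from 8000 nM to 150000 nM.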

Compound 4, half-maximal inhibitory concentration: 84900 nM
Compound 4: the middle estimate sits 2.1-fold (0.33 log units) below what was measured; the range from low to high includes it.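

On the amide-type nitrogen, compound 4 gives an exact reading of 84900 nM. Among these compounds, compound 1, the only earlier compound with the 3,5-dimethyl-1,2-oxazol-4-yl group, offered just a limit. The change from cyclopropyl to 1-methylpiperidin-4-yl is an at least 1.1-fold lower number from compound 1 to compound 4 (0.07 log units; that floor lies within the scatter), so only a floor is known, and it does not establish that this exchange moves the read-out. Exact numbers remain scarce in this assay, with the series still resting heavily on a limit: the limit of > 100000 nM in this assay, at which 2 of the 4 values shown sit.

Open, as far as these compounds go, is whether the ring nitrogen of 1-methylpiperidin-4-yl matters at all, which a cyclohexyl group, a piperidin-4-yl group without the methyl or an open-chain amine on the same nitrogen could test. Also open, from the compounds shown here alone, is how 1-methylpiperidin-4-yl behaves with 1-methyl-1H-pyrazol-4-yl on the shared core.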